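From 2-fluorophenyl to 4-fluorophenyl in compound 3

The source may report more compounds than this note shows. Statements on the series, on what has been measured and on what is new or still open speak of the compounds shown alone.

Among the compounds with values here, only two compounds have numbers so far in a functional assay on A549 cells (Homo sapiens) for antiproliferative activity, read by MTT assay; on this read-out lower numbers stand for stronger inhibition and higher numbers for weaker inhibition. There, compound 1 `COc1cc2c(Oc3ccc(NC(=O)Nc4ccc(Cl)c(C(F)(F)F)c4)cc3)ccnc2cc1OCCCCCCC(=O)NO` gives 5020 nM, and compound 2 `COc1cc2c(Oc3ccc(NC(=O)N/N=C/c4ccccc4F)cc3)ccnc2cc1OCCCCCCC(=O)NO` gives 7780 nM. Within the data shown here, compound 2 therefore sits within the usual scatter of compound 1, the only other measured compound, and neither can be ranked above the other.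

Compound 3 `COc1cc2c(Oc3ccc(NC(=O)N/N=C/c4ccc(F)cc4)cc3)ccnc2cc1OCCCCCCC(=O)NO` differs from compound 2 in a single place: 4-fluorophenyl in place of 2-fluorophenyl on a carbon with a double bond to nitrogen. The two have the same atoms, joined differently, with 4-fluorophenyl in place of 2-fluorophenyl on a carbon with a double bond to nitrogen. Among the measured compounds shown here, no measured pair tests this exchange directly.

For the measured compounds named here, the only step available is a broader one on an amide-type nitrogen, which exchanged a whole group and amounted to a 1.5-fold higher number from compound 1 to compound 2 (0.19 log units; within the scatter). With compound 2 as the reference, that step gives no reason to expect a change beyond the scatter in this assay, and no direction is favoured. The expected step is a 1.1-fold lower number from compound 2 to compound 3 (0.05 log units; within the scatter). Compound 3 is estimated at 7000 nM, with an expected range of 3000 nM to 16000 nM.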

Compound 3, half-maximal inhibitory concentration: 4920 nM
Beside the measured number, compound 3's estimate is 1.4-fold (0.15 log units) above it; measured number inside the range.
By their numbers in this assay, from the lowest: compounds 3, 1 and 2 (each within the scatter of the next).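

In this assay, 4-fluorophenyl in place of 2-fluorophenyl on a carbon with a double bond to nitrogen comes to a 1.6-fold lower number from compound 2 to compound 3 (0.20 log units; within the scatter). Within the data shown here, this is the first direct test of this exchange, and it shows that, for these two fluorophenyl groups at this position, the read-out does not separate compound 2 from compound 3. The broader exchange of groups on an amide-type nitrogen comes to a 1.0-fold lower number from compound 1 to compound 3 (0.01 log units; within the scatter), so compound 3 cannot be ranked against compound 1 either, and no available information bears on why the three numbers stay so close.

From the compounds shown here alone, it remains open whether 3-fluorophenyl, unsubstituted phenyl, or a phenyl carrying a nitrile or an amine in place of the fluorine would give a number beyond the scatter of these three compounds. Also open, going by these compounds, is whether a longer chain, in place of the one ending in the hydroxamic acid, would give a larger step than any of the exchanges seen here.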